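Flipping One Double Bond in a Cytotoxic Chain

This account rests on a few compounds, and the source may have more. Where it says the series, first, only, none or still open, it means among the compounds named here.

Measured so far:
- compound 1, `CC1=C(O)/C(=C/[C@H](C)CCC/C(C)=C/CCc2coc(Cc3ccoc3)c2)OC1=O`: 5.42 ug/mL
- compound 2, `CC1=C(O)/C(=C\[C@H](C)CC/C=C(/C)CCCc2coc(Cc3ccoc3)c2)OC1=O`: 5 ug/mL

Both compounds were tested in a functional assay on XF498 cells (Homo sapiens) for cytotoxicity; a higher number here means that more compound is needed for the effect, a lower number that less compound is needed. In this assay compound 2 gives 5 ug/mL, and compound 1 gives 5.42 ug/mL. Compound 2 shows the lower of the two numbers, but the gap to compound 1 is within the scatter of repeated measurements, so the two compounds cannot be told apart on these values.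

Compound 3, `CC1=C(O)/C(=C/[C@H](C)CC/C=C(/C)CCCc2coc(Cc3ccoc3)c2)OC1=O`, has not yet been measured. It is related to compound 2 by a single change: the two compounds have the same atoms and bonds and differ only in configuration as drawn: 1 of 3 stereo elements differ; a double bond is drawn E in compound 2 and Z in compound 3. Within the data shown here, no step between two measured compounds is available to show how such a change has behaved before.

Because compound 2 gives 5 ug/mL and compound 3 keeps the same atoms and bonds with only the drawn configuration of one double bond differing, the expectation for compound 3 is a number close to that of compound 2, with no step beyond the scatter in either direction. The step of a 1.1-fold higher number from compound 2 to compound 3 (0.04 log units; within the scatter) is therefore expected to be small. For compound 3 the estimate in this assay is 5.5 ug/mL, with a range from 2.5 ug/mL to 12 ug/mL.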

Compound 3, concentration for half-maximal effect: 3.7 ug/mL
Estimate against measurement, compound 3: 1.5-fold (0.17 log units) above; the measured number falls inside the stated range.
By their numbers in this assay, from the lowest: compounds 3, 2 and 1 (each within the scatter of the next).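

Among these compounds, this pair gives the first step between two measured compounds that differ in one place, so the flip of a single double bond can now be read on its own. In this assay that flip gives a 1.4-fold lower number from compound 2 to compound 3 (0.13 log units; within the scatter), which means that on these numbers the E and Z forms at this double bond cannot be told apart in these cells. The comparison is a clean one because no atom enters or leaves and nothing else separates the pair: the fact that compounds 2 and 3 differ only in the configuration as drawn

Still open, on these data alone, is whether the other two stereo elements can be changed just as freely, since this step speaks only for the one double bond that differs here, and only in this one cell line. Also open is what a real change in atoms would do, such as an amine or a carboxylic acid on the chain or a longer chain, as every compound shown carries the same atoms and bonds or the same overall parts, and none of these numbers yet shows a step beyond the scatter.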